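The source may hold more compounds than are shown below. What is called first, only, known or untested is meant among the compounds shown, and "the series" means these compounds.

Compound 1, with the structure `CC(=O)N1N=C(Nc2nc3ccccc3s2)CC1c1ccccc1`, and compound 2, with the structure `CC(=O)N1N=C(Nc2nc3ccccc3s2)CC1c1ccc(Cl)cc1`, share one core and differ in a single place, namely (chloro in place of hydrogen on an aromatic carbon). In a functional assay on the whole organism (Hindlimb, strain albino) with Mus musculus as the target, in the maximal electroshock model, with a stated time of 0.5 h (a lower number here means that less compound is needed, a higher number that more compound is needed for the effect), compound 1 gives 315 umol/kg, while compound 2 gives 209 umol/kg; the step of a 1.5-fold lower number from compound 1 to compound 2 (0.18 log units; within the scatter) is small. Compound 3, with the structure `Cc1ccc2nc(NC(=O)/C=C/c3ccccc3)sc2c1`, is built on a different core, and the difference between the two cores is not broken down here; in this assay compound 3 gives 380 umol/kg, a number close to those of compound 1 and compound 2. Compound 4, with the structure `Cc1ccc2nc(NC(=O)/C=C/c3ccc(Cl)cc3)sc2c1`, has not yet been measured. It differs from compound 3 by chloro in place of hydrogen on an aromatic carbon, the same kind of change as that from compound 1 to compound 2, and the two place descriptions read alike. Because the earlier step was a 1.5-fold lower number from compound 1 to compound 2 (0.18 log units; within the scatter), compound 4 is expected to move by a step of about a 1.3-fold lower number from compound 3 to compound 4 (0.12 log units; within the scatter), resting only on that one precedent. The value for compound 4 is thus estimated at 290 umol/kg, with a range from 170 umol/kg to 500 umol/kg.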

Compound 4, dose for half-maximal effect: 152 umol/kg
For compound 4 the middle estimate is 1.9-fold (0.28 log units) above the measured one, outside the stated range (below it).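

In this assay, the change from phenyl to 4-chlorophenyl comes with a 2.5-fold lower number from compound 3 to compound 4 (0.40 log units; beyond the scatter), a modest step that lies beyond the scatter. Set beside the earlier step on the other core, the new step cannot be told apart from it: the same change on two cores in this assay, a 1.5-fold lower number (0.18 log units; within the scatter) from compound 1 to compound 2 and a 2.5-fold lower number (0.40 log units; beyond the scatter) from compound 3 to compound 4, 1.7-fold (0.22 log units) apart, within the scatter of two such steps. This shows that, on these two cores, the change carried over with a size that is consistent within the scatter, but the pairs are only two, the earlier step alone is within the scatter, and nothing here shows that the change would carry to any further core or why it acts as it does.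

The compounds shown leave open whether fluoro, methoxy or a nitrile in the same place would give a similar step, and whether chloro on another carbon of that ring would do so. From the compounds shown here alone, it also remains open how an amine or a carboxylic acid at this place would behave on either core.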